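The compounds below may be only part of what the source reports. "The series", "measured", "known", "first", "only" and "open" are said of these compounds alone.

Measured in an assay on cells for inhibition of Amine oxidase [flavin-containing] B (Homo sapiens), read by fluorescence, with stated times of 10 min and 20 min, tested at 25 uM; a higher number here means more inhibition at the concentration tested (going by the name of the read-out), a lower number less inhibition:
Compound 1, `COc1c(C)c(C/C=C(\C)CCC=C(C)C)c(OC)c(OC)c1OC`, gives 38%.
Compound 2, `COc1c(C)c(C/C=C(\C)CC/C=C(\C)CCC=C(C)C)c(OC)c(OC)c1OC`, gives 15.2%.
Compound 3, `CC(C)=CCC1=C(C)C(=O)C(O)=C(O)C1=O`, gives 38.3%.

Compound 2 arises from compound 1 by one change: 3-methylbut-2-en-1-yl in place of hydrogen on a saturated chain carbon bound to a double-bonded chain carbon. This step gave a number 22.8 percentage points lower from compound 1 to compound 2 (beyond the scatter). Compound 3 has a different core; how its core differs from that of compound 1 is not broken down here, and the two values of compound 1 and compound 3 lie within the scatter of each other.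

Compound 4, `CC(C)=CCC/C(C)=C/CC1=C(C)C(=O)C(O)=C(O)C1=O`, is not yet measured. It differs from compound 3 by 3-methylbut-2-en-1-yl in place of hydrogen on a saturated chain carbon bound to a double-bonded chain carbon, the same change that leads from compound 1 to compound 2. Since this change lowered the read-out in this assay by a number 22.8 percentage points lower from compound 1 to compound 2 (beyond the scatter), a step of similar size is expected for compound 4, namely a number 20.3 percentage points lower from compound 3 to compound 4 (beyond the scatter). The estimate for compound 4 in this assay is therefore 18%, expected to fall between 5% and 33%.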

Compound 4, a percentage reported as inhibition, at one concentration (the size of the read-out at that concentration, not a potency): 92.2%
Compound 4: the middle estimate sits 74.2 percentage points below what was measured; the measured number lies above the stated range.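

On the core of compound 3, 3-methylbut-2-en-1-yl in place of hydrogen on a saturated chain carbon bound to a double-bonded chain carbon gave a number 53.9 percentage points higher from compound 3 to compound 4 (beyond the scatter) in this assay. Set beside the earlier step, the change did not carry from one core to the other, even in direction: the same change on two cores in this assay, a number 22.8 percentage points lower (beyond the scatter) from compound 1 to compound 2 and a number 53.9 percentage points higher (beyond the scatter) from compound 3 to compound 4, 76.7 percentage points apart, beyond the scatter of two such steps

Among these compounds, with only one pair on each core, this shows that the outcome of the change differed between these two cores, but it does not show why, or what the change would do on any other core.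

The compounds shown leave open whether a longer chain would continue the rise on the core of compound 3 and the fall on the core of compound 1. They also leave open whether a fully saturated chain would follow the same course on either core.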